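This account rests on a few compounds, and the source may have more. Where it says the series, first, only, none or still open, it means among the compounds named here.

Measured so far in a functional assay on the whole organism with Rattus norvegicus as the target; on this read-out lower numbers stand for an effect already at smaller amounts and higher numbers for an effect only at larger amounts of compound:
compound 1, `CC(C)c1ccc2nc(N)sc2c1` — > 10 mg/kg
compound 2, `Nc1nc2ccc(OC(F)(F)C(F)F)cc2s1` — 8.5 mg/kg
compound 3, `Cn1c(=N)sc2cc(OC(F)(F)F)ccc21` — 5 mg/kg

In this assay, going by the values given here, compound 1 gives only a limit, > 10 mg/kg, and no number; it is the one value of the three that sits at the limit of > 10 mg/kg in this assay, at which 1 of the 3 values shown sits. Compound 2 gives 8.5 mg/kg. Compound 3 gives 5 mg/kg, the lower of the two numbers, though its gap to compound 2 lies within the usual scatter, so the two cannot be ranked against each other.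

The step now followed leads from compound 3 to compound 4, `N=c1sc2cc(OC(F)(F)F)ccc2n1CC(=O)O`, which has not yet been measured in this assay. The change is carboxy in place of hydrogen on a saturated chain carbon bound to an aromatic nitrogen. No step between two measured compounds is available here, so nothing in the data sets a precedent for this change, and no cause can be named for whatever it may bring.

The account expects for compound 4 a dose of 8 mg/kg, with a range from 3 mg/kg to 25 mg/kg. This estimate means a step of a 1.6-fold higher number from compound 3 to compound 4 (0.20 log units; within the scatter), a modest move toward a higher number that is expected to sit at the edge of the scatter rather than clearly beyond it.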

Compound 4, dose for half-maximal effect: > 10 mg/kg
Compound 4 was reported as a limit; the forecaster's own chance of this, stated with the estimate: 35%; middle value at least 1.2-fold (0.09 log units) away from the limit.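

In this assay compound 4 gives > 10 mg/kg, which is a limit and not a number. Methyl to carboxymethyl is the first change at this position that can be read, and it amounts to an at least 2.0-fold higher number from compound 3 to compound 4 (0.30 log units; that floor lies within the scatter), so the step has a floor but no known size, and the data name no cause for it. Compound 4 thus stands with compound 1 at the same limit, and the two cannot be ranked against each other: the limit of > 10 mg/kg in this assay, at which 2 of the 4 values shown sit.

The compounds shown leave open how far compound 4 lies beyond its limit, and whether the outcome follows the carboxy group itself or the chain that carries it. As far as these compounds go, whether an ester, an amide or an amine on this chain, or a carboxylic acid on a longer chain, would give a number in this assay also remains open.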